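This account rests on a few compounds, and the source may have more. Where it says the series, first, only, none or still open, it means among the compounds named here.

Measured so far:
- compound 1 `COc1ccc(N2CCN(C(=S)SCc3ccc4nc(N)nc(N)c4c3)CC2)cc1` gives 1590 nM
- compound 2 `Cc1ccc(N2CCN(C(=S)SCc3ccc4nc(N)nc(N)c4c3)CC2)cc1` gives 2190 nM
- compound 3 `Nc1nc(N)c2cc(CSC(=S)N3CCN(c4ccc(Cl)cc4)CC3)ccc2n1` gives 5210 nM

All three were tested in a functional assay on A549 cells (Homo sapiens) for antiproliferative activity, read by MTT assay, with a stated time of 72 h; on this read-out higher numbers stand for weaker inhibition and lower numbers for stronger inhibition. Compound 1 has the lowest number of the three, though the gap to compound 2 a 1.4-fold higher number from compound 1 to compound 2 (0.14 log units; within the scatter) is within the scatter, so the two cannot be ranked. Compound 4 `Nc1nc(N)c2cc(CSC(=S)N3CCN(c4ccc(Cl)c(Cl)c4)CC3)ccc2n1` differs from compound 1 in one place: 3,4-dichlorophenyl in place of 4-methoxyphenyl on an amine nitrogen in a ring. Within the data shown here, two measured steps bear on this. Replacing methoxy by chloro gave a 3.3-fold higher number from compound 1 to compound 3 (0.52 log units; beyond the scatter), and replacing methyl by chloro gave a 2.4-fold higher number from compound 2 to compound 3 (0.38 log units; beyond the scatter). Both point the same way, toward higher numbers, so a modest step upward is expected. The expected step is a 3.8-fold higher number from compound 1 to compound 4 (0.58 log units; beyond the scatter). Compound 4 is thus estimated at 6000 nM, with a range from 2500 nM to 15000 nM.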

Compound 4, half-maximal inhibitory concentration: 2940 nM
Beside the measured number, compound 4's estimate is 2.0-fold (0.31 log units) above it, and the stated range covers the measured number.
By their numbers in this assay, from the lowest: compounds 1, 2, 4 and 3 (each within the scatter of the next, the first and the last beyond it).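

In this assay the 3,4-dichlorophenyl group on the ring nitrogen gives a 1.8-fold higher number from compound 1 to compound 4 (0.27 log units; within the scatter) and a 1.3-fold higher number from compound 2 to compound 4 (0.13 log units; within the scatter) and, with its added chloro, a 1.8-fold lower number from compound 3 to compound 4 (0.25 log units; within the scatter) as well. Chloro on this aromatic ring therefore does not always bring a step beyond the scatter from the 4-methoxyphenyl compound, as it did for compound 3. Nothing available explains this result. Going by these compounds, how this position would respond to an amine or a carboxylic acid on the phenyl ring remains open.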